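Swapping the aryl group on a shared core: cytotoxicity outlook

The source may report more compounds than this note shows. Statements on the series, on what has been measured and on what is new or still open speak of the compounds shown alone.

Compound 1 `C=Cc1ccc(-c2cc(C)c3ncc(CSCCc4ccccc4)n3c2)cc1` serves as the reference. In an ADME assay on HEL cells (Homo sapiens) for cytotoxicity, with a stated time of 3 days (a higher number here means that more compound is tolerated, a lower number that less compound is tolerated), compound 1 gives 14 ug/mL, the second highest of three numbers: compound 2 `Cc1cc(-c2ccc3[nH]ccc3c2)cn2c(CSCCc3ccccc3)cnc12` gives 26 ug/mL and compound 3 `Cc1cc(N2CCCC2)cn2c(CSCCc3ccccc3)cnc12` gives 12 ug/mL. The change leading to compound 4 `Cc1cc(Sc2ccc(N)cc2)cn2c(CSCCc3ccccc3)cnc12` is (4-aminophenyl)sulfanyl in place of 4-vinylphenyl on an aromatic carbon. Two measured steps start at the same position of the core: a 1.9-fold higher number from compound 1 to compound 2 (0.27 log units; within the scatter) and a 1.2-fold lower number from compound 1 to compound 3 (0.07 log units; within the scatter), whereas a 2.2-fold lower number from compound 2 to compound 3 (0.34 log units; beyond the scatter). Because a 1.9-fold higher number from compound 1 to compound 2 (0.27 log units; within the scatter) and a 1.2-fold lower number from compound 1 to compound 3 (0.07 log units; within the scatter) both stay within the scatter, the step to compound 4 is expected to be a 1.1-fold higher number from compound 1 to compound 4 (0.03 log units; within the scatter), none beyond the scatter. In this assay compound 4 is therefore estimated at 15 ug/mL, within a range from 7 ug/mL to 30 ug/mL.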

Compound 4, half-maximal cytotoxic concentration: 23 ug/mL
Compound 4: the middle estimate sits 1.5-fold (0.19 log units) below what was measured; the measured number falls inside the stated range.
By their numbers in this assay, from the lowest: compounds 3, 1, 4 and 2 (each within the scatter of the next, the first and the last beyond it).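

The (4-aminophenyl)sulfanyl group, the first substituent here joined to the core through sulfur, stays within the scatter of all three earlier groups in this assay (a 1.6-fold higher number from compound 1 to compound 4 (0.22 log units; within the scatter); a 1.9-fold higher number from compound 3 to compound 4 (0.28 log units; within the scatter); a 1.1-fold lower number from compound 2 to compound 4 (0.05 log units; within the scatter)). Among these compounds, only the gap from compound 2 to compound 3 remains beyond the scatter. No available measurement explains these numbers.

From the compounds shown here alone, it remains open whether a carboxylic acid at this position would shift the number beyond the scatter. The same question applies to a 4-aminophenyl group joined through oxygen instead of sulfur.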